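The source may report more compounds than this note shows. Statements on the series, on what has been measured and on what is new or still open speak of the compounds shown alone.

Measured compounds:
compound 1 `N/C(=N\NC(=S)N1CCSCC1)c1ccccn1` — 39.7%
compound 2 `Cc1cccc(/C(N)=N/NC(=S)N2CCCCC2)n1` — 68.9%
compound 3 `Cc1ccnc(/C(N)=N/NC(=S)N2CCCCC2)c1` — 23.9%

In a functional assay on HeLa cells (Homo sapiens) for cytotoxicity, read by MTT assay, with a stated time of 72 h, tested at 3 uM (a higher number here means more inhibition of growth at the concentration tested, a lower number less inhibition of growth), compound 3 stands lowest of the three numbers. Compound 1 is nearest, with a number higher by an amount beyond the scatter, and compound 2 lies furthest, higher by a margin well beyond the scatter. Among the compounds with values here, no pair of the measured compounds differs in one place only, so no single step can be read directly from them.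

Compound 4 `N/C(=N\NC(=S)N1CCCCC1)c1ccccn1` has not yet been measured. Compared with compound 3, the change is hydrogen in place of methyl on an aromatic carbon. Compound 1 likewise carries no methyl on its six-membered aromatic ring with 1 nitrogen, and its value in this assay sits above that of compound 3; compound 1 differs from compound 4 elsewhere, however, so it serves only as a loose pointer.

On that basis a modest rise from compound 3 to compound 4 is expected, of the order of a number 16.1 percentage points higher from compound 3 to compound 4 (beyond the scatter), though a result within the scatter of compound 3 would not surprise. The estimate for compound 4 in this assay is 40%, with a likely range from 22% to 60%.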

Compound 4, percent growth inhibition at one concentration: 49.2%
For compound 4 the middle estimate is 9.2 percentage points below the measured one; measured number inside the range.
By their numbers in this assay, from the lowest: compound 3; then compounds 1 and 4 (each within the scatter of the next); then compound 2.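

Working notes on the series: in this assay hydrogen in place of methyl on an aromatic carbon, opposite the ring nitrogen, gives a number 25.3 percentage points higher from compound 3 to compound 4 (beyond the scatter) and so shows that this methyl goes with lower growth inhibition at the concentration tested. The same exchange on a different aromatic carbon of the ring gives a number 19.7 percentage points lower from compound 2 to compound 4 (beyond the scatter) in the opposite direction, so in these two pairs the direction of the step depends on which ring carbon carries the methyl, and no single reading of methyl covers both. Piperidin-1-yl in place of thiomorpholin-4-yl on a thiocarbonyl carbon gives a number 9.5 percentage points higher from compound 1 to compound 4 (within the scatter) and thus does not separate the two rings in this series, at least with the unsubstituted aromatic ring.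

The data shown offer no measurement that explains why the two methyl steps run in opposite directions. Still open, on these data alone, is whether ethyl, methoxy or an amine on the carbon opposite the ring nitrogen would follow the methyl of compound 3, and whether either methyl step would carry over to the thiomorpholin-4-yl series.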